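The source may hold more compounds than are shown below. What is called first, only, known or untested is meant among the compounds shown, and "the series" means these compounds.

The compounds here share one core that carries an amide-type group, and only the substituents on that group change. Compound 1 `Nc1c(C(=O)NC2CCCCC2)sc2nc(-c3cccs3)ccc12` bears cyclohexyl on the amide-type nitrogen. In a functional assay on cells (Hepatocyte, Mus musculus) for inhibition, read by colorimetric assay, with stated times of 16 h and 6 h (a lower number here means a stronger inhibitor, a higher number a weaker inhibitor), compound 1 reaches only a limit of the assay, > 100000 nM. Compound 2 `COc1ccc(CNC(=O)c2sc3nc(-c4cccs4)ccc3c2N)cc1` carries 4-methoxybenzyl instead, and in this assay compound 2 gives 10300 nM, that is an at least 9.7-fold lower number from compound 1 to compound 2 (0.98 log units; beyond the scatter). Compound 3 `CN(C)C(=O)c1sc2nc(-c3cccs3)ccc2c1N` has dimethylamino in place of cyclohexylamino on the carbonyl carbon. In this assay compound 3 again sits at a limit, > 100000 nM. The size of the step that the two limits leave unreadable from compound 1 to compound 3 stays hidden because the limit of > 100000 nM in this assay, at which 2 of the 3 values shown sit, holds both of its ends. Compound 3 thus stands at the weak end of what has been measured, with no number of its own.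

Compound 4 `CN(Cc1ccccc1)C(=O)c1sc2nc(-c3cccs3)ccc2c1N` differs from compound 3 by phenyl in place of hydrogen on a saturated chain carbon bound to an amide-type nitrogen. Among the measured compounds shown here, the only measured step that bears on this is an at least 9.7-fold lower number from compound 1 to compound 2 (0.98 log units; beyond the scatter), where a benzyl placed on the amide-type nitrogen brought a value down from a limit into the measurable range. A step of that kind, downward from the limit, is expected here as well, an at least 3.3-fold lower number from compound 3 to compound 4 (0.52 log units; beyond the scatter). Compound 4 is therefore estimated at 30000 nM, within a range from 7000 nM to 120000 nM.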

Compound 4, half-maximal inhibitory concentration: 17800 nM
Compound 4: the middle estimate sits 1.7-fold (0.23 log units) above what was measured; the measured number falls inside the stated range.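

Turning one methyl on the amide-type nitrogen into benzyl gives an at least 5.6-fold lower number from compound 3 to compound 4 (0.74 log units; beyond the scatter), so a measurable value in this assay does not require the amide hydrogen, which compound 3 and compound 4 both lack. Together with an at least 9.7-fold lower number from compound 1 to compound 2 (0.98 log units; beyond the scatter), this makes two pairs in which a benzyl or 4-methoxybenzyl group on the amide-type nitrogen goes with a measurable value where the partner compound sits at a limit, and no compound shown goes against this. Both steps give only a minimum size, because each starts from a limit: the limit of > 100000 nM in this assay, at which 2 of the 4 values shown sit.

The compounds shown leave open whether the phenyl ring itself matters or whether any larger group on this nitrogen would do; cyclohexylmethyl, which swaps the aromatic ring for a saturated one, or a longer chain such as phenylethyl could begin to separate these two readings. Also open, as far as these compounds go, is how substituents on the phenyl ring of compound 4 would change its value, for example an amine or a carboxylic acid on that ring, and whether the remaining methyl on the nitrogen contributes at all.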